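A few compounds are considered here, and "the series" means these few. Any claim that something is new, unique, unknown or untested is made for them only; others in the source may bear on it.

Compound 1 `Cc1nnc(SCc2ccccc2)n1N1C(=O)c2ccccc2C1=O`: > 200000 nM
Compound 2 `CCOC(=O)CSc1nnc(C)n1N1C(=O)c2ccccc2C1=O`: > 200000 nM
Compound 3 `Cc1nnc(SCC(=O)c2ccc(Cl)cc2)n1N1C(=O)c2ccccc2C1=O`: > 200000 nM

The three measured compounds were tested in a functional assay on HepG2 cells (Homo sapiens) for cytotoxicity, read by MTT assay, with a stated time of 48 h; a lower number here means a stronger inhibitor, a higher number a weaker inhibitor. Compound 1 reached only the limit of the assay there, > 200000 nM. Compound 2 likewise returned only a limit, > 200000 nM. Compound 3 too gave only a limit, > 200000 nM. All three therefore sit at the limit of > 200000 nM in this assay, at which 3 of the 3 values shown sit, and the steps between them, a step that the two limits leave unreadable from compound 1 to compound 2, a step that the two limits leave unreadable from compound 1 to compound 3 and a step that the two limits leave unreadable from compound 2 to compound 3, cannot be given a size. Compound 3 thus stands at no number at all; it is known only as a limit, as are the two other values.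

Compound 4 `CSc1nnc(C)n1N1C(=O)c2ccccc2C1=O` has not yet been measured. It differs from compound 3 in one place: hydrogen in place of (4-chlorophenyl)carbonyl on a saturated chain carbon bound to a sulfur. Within the data shown here, none of the measured steps is readable, so none of them bears on this change with a size; what they show is only that three different groups on that chain carbon bound to a sulfur all left the read-out at the limit. The expectation for compound 4 in this assay is therefore that it also stays at the limit, with the step that the limit leaves unreadable from compound 3 to compound 4 expected to remain unreadable in the same way. Compound 4 is estimated at 250000 nM, in a range from 100000 nM to 1000000 nM, and most likely to be reported only as a limit.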

Compound 4, half-maximal inhibitory concentration: > 200000 nM
Compound 4 ended at the assay's limit (the forecaster's own chance of this, stated with the estimate: 85%); the middle value lies beyond the limit too.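

In this assay compound 4 gave only a limit, > 200000 nM. Among these compounds, its steps from compound 1, compound 2 and compound 3 cannot be read, so no new step can be sized, and all four compounds stand together: the limit of > 200000 nM in this assay, at which 4 of the 4 values shown sit. The compounds shown leave open whether any group on the saturated chain carbon bound to a sulfur would give a measurable value in this assay.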